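A few compounds are considered here, and "the series" means these few. Any claim that something is new, unique, unknown or untested is made for them only; others in the source may bear on it.

Of the compounds shown here, three have been measured in a functional assay on PC-3 cells (Homo sapiens) for cytotoxicity, read by MTT assay, with a stated time of 48 h; a higher number here means a weaker inhibitor, a lower number a stronger inhibitor. Compound 1 `CC1=NN(C(=O)COc2ccc(Cl)cc2)C(c2cc(Br)ccc2O)C1` gives 49000 nM, compound 2 `CC(=O)Oc1ccccc1C1CC(C)=NN1C(=O)CCl` gives 3580 nM, and compound 3 `CC(C)CNCC(=O)N1N=C(c2cc3ccccc3oc2=O)CC1c1ccccc1` gives 1920 nM. Of the three numbers, that of compound 3 is the lowest, but the gap to compound 2 lies within the scatter of the assay, so the two cannot be set in order; only compound 1 stands clearly apart, its number being well above that of compound 3.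

The next compound in the series is compound 4 `CN1CCN(CC(=O)N2N=C(c3cc4ccccc4oc3=O)CC2c2ccccc2)CC1`. It keeps the whole of compound 3 apart from one change at the amide end: 4-methylpiperazin-1-yl in place of isobutylamino on a saturated chain carbon bound to a carbonyl carbon. The group that enters brings a ring and loses the single hydrogen-bond donor, while the rest of the molecule is untouched.

Among the compounds with values here, no measured pair in this set shows what such a change does in this assay, so there is no step to lean on. Compound 4 is expected to land close to compound 3, with the step of a 1.3-fold higher number from compound 3 to compound 4 (0.11 log units; within the scatter) expected to stay within the scatter rather than shift the number in either direction. On that basis compound 4 is estimated at 2500 nM in this assay, within a range from 800 nM to 8000 nM.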

Compound 4, half-maximal inhibitory concentration: 25800 nM
The estimate for compound 4 lay 10-fold (1.01 log units) below the measured number; the measured number lies above the stated range.
By their numbers in this assay, from the lowest: compounds 3 and 2 (each within the scatter of the next); then compounds 4 and 1 (each within the scatter of the next).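

At this saturated chain carbon bound to a carbonyl carbon, the exchange is far from silent in this assay: 4-methylpiperazin-1-yl in place of isobutylamino goes with a 13-fold higher number from compound 3 to compound 4 (1.13 log units; beyond the scatter) on an otherwise unchanged molecule. Within the data shown here, this is the first reading of a single change in the set, as the earlier compounds differ in more than one place and could not show how much the number depends on this group alone. The step shows that the number follows the group at this place closely, but the exchange brings in a ring, removes the hydrogen-bond donor and adds a second ring nitrogen all at once, and nothing available separates these features or explains the step.

The compounds shown leave open whether piperidin-1-yl, morpholin-4-yl or an open-chain dimethylamino group at this place would stay with compound 3 or go with compound 4. They also leave open whether a longer chain carrying 4-methylpiperazin-1-yl would give a similar number, and whether the same exchange has a comparable effect on a different core.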